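This account rests on a few compounds, and the source may have more. Where it says the series, first, only, none or still open, it means among the compounds named here.

Of the compounds shown here, two have been measured in an assay on NK92 cells for inhibition of interleukin-2 (Homo sapiens), read by AlphaScreen, with stated times of 30 min and 1 h; a lower number here means a stronger inhibitor, a higher number a weaker inhibitor. Compound 1 `Cn1c(Cc2nn(C)c(=O)c3ccccc23)nnc1SCC(=O)Nc1ccc(Cl)cc1Cl` gives 7700 nM, while compound 2 `Cn1c(Cc2nn(C)c(=O)c3ccccc23)nnc1SCCCCCCCC(=O)Nc1ccc(Cl)cc1Cl` gives 350 nM, the lower of the two numbers and the stronger inhibitor, with a gap to compound 1 beyond the scatter. Compound 3 `CCOC(CCn1c(Cc2nn(C)c(=O)c3ccccc23)nnc1SCCCCCCCC(=O)Nc1ccc(Cl)cc1Cl)OCC` is not yet measured and differs from compound 2 by 2,2-diethoxyethyl in place of hydrogen on a saturated chain carbon bound to an aromatic nitrogen. Nothing measured here shows the effect of such a change, so only a modest step in this assay is expected, in either direction, the estimate being a 1.4-fold higher number from compound 2 to compound 3 (0.15 log units; within the scatter). Compound 3 is therefore expected near 500 nM, in the range from 150 nM to 2000 nM.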

Compound 3, half-maximal inhibitory concentration: > 30000 nM
Compound 3 gave a limit, no number (the forecaster's own chance of this, stated with the estimate: 5%); at least 60-fold (1.77 log units) between middle value and limit.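

In this assay, the saturated chain carbon bound to an aromatic nitrogen proves far from indifferent: 2,2-diethoxyethyl in place of hydrogen there gives an at least 85-fold higher number from compound 2 to compound 3 (1.93 log units; beyond the scatter). Compounds 1 and 2 share the same group at this place, so they said nothing about it. Compound 3 stands as a limit of the assay, not a number: the limit of > 30000 nM in this assay, at which 1 of the 3 values shown sits.

Going by these compounds, whether ethyl, or a propyl chain ending in an amine or a carboxylic acid, would keep a value near that of compound 2 remains open. Also open, on these data alone, is whether the step belongs to the two ethoxy groups or to the chain that carries them.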